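From trifluoromethoxy to fluoro on the shared core

This account rests on a few compounds, and the source may have more. Where it says the series, first, only, none or still open, it means among the compounds named here.

Compound 1 `CCOC(=O)c1c(-c2cccc(OC)c2)[nH]c2cc(OC)ccc2c1=O` gives > 21500 nM as a limit
Compound 2 `CCOC(=O)c1c(-c2cccc(OCC)c2)[nH]c2cc(OC)ccc2c1=O` gives > 21500 nM as a limit
Compound 3 `CCOC(=O)c1c(-c2cccc(OC(F)(F)F)c2)[nH]c2cc(OC)ccc2c1=O` gives > 21500 nM as a limit

In an ADME assay on HepG2 cells (Homo sapiens) for cytotoxicity, read by luminescence, with a stated time of 72 h (on this read-out lower numbers stand for an effect already at smaller amounts and higher numbers for an effect only at larger amounts of compound), compound 3 gives > 21500 nM as a limit and not as a number. Compound 3 shares the limit of > 21500 nM in this assay, at which 3 of the 3 values shown sit, so it cannot be ranked against the other two. Compound 4 `CCOC(=O)c1c(-c2cccc(F)c2)[nH]c2cc(OC)ccc2c1=O` keeps the core of compound 3 and carries one change, fluoro in place of trifluoromethoxy on an aromatic carbon. Three measured steps come closest, namely a step that the two limits leave unreadable from compound 1 to compound 2 and a step that the two limits leave unreadable from compound 1 to compound 3 and a step that the two limits leave unreadable from compound 2 to compound 3 (none gives a size to carry over). All three alter only the group on the oxygen, whereas this change removes that oxygen as well. No step beyond the scatter is therefore expected in this assay and no direction can be read. The expected change is small (a step that the limit leaves unreadable from compound 3 to compound 4). Compound 4 is estimated at 22000 nM with a range from 12000 nM to 40000 nM and may well turn out only as a limit.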

Compound 4, half-maximal effective concentration: > 21500 nM
Compound 4 was reported as a limit; the forecaster's own chance of this, stated with the estimate: 85%; the middle value is on the limit's open side.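

In this assay, among the compounds shown here, compound 4 also gives only a limit, so no step among compounds 1, 2, 3 and 4 can be read, and all four share the same limit: the limit of > 21500 nM in this assay, at which 4 of the 4 values shown sit. Left open is where each of the four truly lies and whether these changes on the shared core shift that value at all.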